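Oxazole series: monkey oral exposure, amide to imidazole swap

This account rests on a few compounds, and the source may have more. Where it says the series, first, only, none or still open, it means among the compounds named here.

Measured compounds:
compound 1 `CCCCN(c1nc2c(C(=O)NC)cccc2o1)[C@H](C)c1ccc(-c2ccccc2-c2nnn[nH]2)cc1` — 25.7 ng.h/mL
compound 2 `C[C@H](c1ccc(-c2cc(F)ccc2-c2nc(=O)o[nH]2)cc1)N(CC1CC1)c1nc2c(C(=O)O)cccc2o1` — 4410 ng.h/mL
compound 3 `CCCCN(c1nc2c(C(=O)O)cccc2o1)[C@H](C)c1ccc(-c2cc(Cl)ccc2-c2nc(=O)o[nH]2)cc1` — 1040 ng.h/mL

In an ADME assay on the whole organism (Macaca fascicularis) for pharmacokinetics, read by LC-MS, using cassette dosing, at a dose of 1 mg/kg by the oral route (a lower number here means less compound in the circulation, a higher number more compound in the circulation at the dose given), compound 1 gives 25.7 ng.h/mL, the lowest of the three numbers. Compound 3 sits nearest to it, with a gap beyond the scatter, and compound 2 furthest, also beyond the scatter. Going by the values given here, no single-point step between any two of the measured compounds can be set out, as each pair differs in more than one place, so what the numbers show is only that compound 1 is the one with the least exposure.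

Compound 4 `CCCCN(c1nc2c(-c3nccn3C)cccc2o1)[C@H](C)c1ccc(-c2ccccc2-c2nnn[nH]2)cc1` is the untested analogue of compound 1. It differs at one place: 1-methyl-1H-imidazol-2-yl in place of methylcarbamoyl on an aromatic carbon. Among the compounds with values here, no measured pair reports the effect of this change, so the size of the step from compound 1 is open. A modest rise in exposure is expected, around the edge of the usual scatter, and the expected step is a 2.3-fold higher number from compound 1 to compound 4 (0.37 log units; beyond the scatter). For compound 4 the estimated value in this assay is 60 ng.h/mL, with a range from 10 ng.h/mL to 400 ng.h/mL.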

Compound 4, area under the concentration-time curve: 152 ng.h/mL
Beside the measured number, compound 4's estimate is 2.5-fold (0.40 log units) below it; the measured number falls inside the stated range.
By their numbers in this assay, from the lowest: compound 1; then compound 4; then compound 3; then compound 2.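

Going by these compounds alone, at the aromatic carbon ortho to a fused ring, this assay gives the first single-place comparison: 1-methyl-1H-imidazol-2-yl in place of methylcarbamoyl produces a 5.9-fold higher number from compound 1 to compound 4 (0.77 log units; beyond the scatter) and this step lies beyond the scatter. In this pair, exchanging methylcarbamoyl, with its hydrogen-bond donor, for a five-membered aromatic ring with no donor raises the number, so the amide is not needed at this position to retain oral exposure. No supporting data bear on the origin of the step.

Still open, as far as these compounds go, is how a primary amide, or an imidazol-2-yl without the methyl group, would read at the same carbon in this assay and thus whether the ring or its methyl group accompanies the rise. From the compounds shown here alone, whether the step carries over to other substituents elsewhere on the core of compound 1 also remains open.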